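Changing the Chain End of Compound 3

The compounds below may be only part of what the source reports. "The series", "measured", "known", "first", "only" and "open" are said of these compounds alone.

In a functional assay on MDA-MB-231 cells (Homo sapiens) for antiproliferative activity, read by MTT assay (a lower number here means a stronger inhibitor, a higher number a weaker inhibitor), three compounds with long chains on a shared core give the same reading. Compound 1 `CCCC/C=C\CCCCCCCCCc1cc(=O)c2c(O)cc(O)c(C)c2o1` gives 6790 nM, compound 2 `CC/C=C\C/C=C\C/C=C\CCCCCCCc1cc(=O)c2c(O)cc(OCOC)c(C)c2o1` gives 6790 nM, and compound 3 `CCCCCCCCCCCCCCCc1cc(=O)c2c(O)cc(O)c(C)c2o1` gives 6790 nM. Compound 3 therefore stands level with the other two.

The next compound, compound 4 `CC/C=C\C/C=C\C/C=C\CCCCCCCc1cc(=O)c2c(O)cc(O)c(C)c2o1`, is not yet measured. It changes the end of the chain of compound 3: a group of 10 heavy atoms (10 carbon; no ring) in place of a group of 8 heavy atoms (8 carbon; no ring), on a saturated chain carbon, seven bonds along the chain from an aromatic carbon. The entering group has three double bonds outside aromatic rings.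

Among the measured compounds shown here, only one measured step bears directly on this kind of change. The step of no change at the digits printed from compound 1 to compound 3 (within the scatter) concerns the saturation of a chain end and is small. Compound 2, which also has an unsaturated chain, gives 6790 nM, again level with the others. With so few compounds, this is limited evidence, but it points to no clear shift in either direction in this assay.

The expected size of no change at the digits printed from compound 3 to compound 4 (within the scatter) is nothing beyond the scatter. Compound 4 is estimated at 6790 nM, with an expected range of 3400 nM to 13500 nM.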

Compound 4, half-maximal inhibitory concentration: 6790 nM
Compound 4: the middle estimate sits on the measured number at the digits printed; low and high end bracket the measured number.
By their numbers in this assay, from the lowest: compounds 1, 2, 3 and 4 (each within the scatter of the next).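

Octyl giving way to the group with three double bonds, on a saturated chain carbon, seven bonds along the chain from an aromatic carbon, gives no change at the digits printed from compound 3 to compound 4 (within the scatter) in this assay and the exchange listed for the other saturated-carbon pair gives no change at the digits printed from compound 1 to compound 4 (within the scatter) as well, so the three double bonds leave the reading where it stood at this place. Hydrogen in place of methoxymethyl on an oxygen on an aromatic ring gives no change at the digits printed from compound 2 to compound 4 (within the scatter) and is the first reading of that oxygen as a single change. No measurement shown offers an explanation for these matching readings.

The compounds shown do not tell whether any chain end can move the reading in this assay at all. A much shorter chain, or a carboxylic acid or an amine at the chain end, lies outside them.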